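This account rests on a few compounds, and the source may have more. Where it says the series, first, only, none or still open, it means among the compounds named here.

Measured compounds:
compound 1 `C=C(Br)C(=O)Nc1cccc(-c2cn3nc(-c4ccccc4)sc3n2)c1` — 600 nM
compound 2 `COc1ccc(-c2nn3cc(-c4cccc(N)c4)nc3s2)cc1OC` — 16000 nM
compound 3 `C=C(Br)C(=O)Nc1cccc(-c2cn3nc(-c4cccc(OC)c4)sc3n2)c1` — 580 nM

In a functional assay on L1210 cells (Mus musculus) for inhibition, read by cell counting, with a stated time of 2 days (a higher number here means a weaker inhibitor, a lower number a stronger inhibitor), compound 3 gives the lowest number of the three, but its gap to compound 1 is within the scatter, so the two cannot be ranked against each other. Compound 2 stands far away: in this assay compound 2 gives a higher number than compound 3, a gap well beyond the scatter.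

Compound 4 `COc1cccc(-c2nn3cc(-c4cccc(N)c4)nc3s2)c1` has not been measured. It differs from compound 3 in one place: hydrogen in place of (1-bromoethenyl)carbonyl on a nitrogen on an aromatic ring. For the measured compounds named here, the only measured single step, a 1.0-fold lower number from compound 1 to compound 3 (0.01 log units; within the scatter), concerns a different part of the molecule and says nothing about removing the (1-bromoethenyl)carbonyl group. The nearest guide is compound 2, which also carries a plain amino group and differs from compound 3 in a second place as well; its much higher number suggests that losing this group costs a great deal. A large rise in this assay is therefore expected for compound 4, corresponding to a step of a 26-fold higher number from compound 3 to compound 4 (1.41 log units; beyond the scatter). Compound 4 is expected to give about 15000 nM, with a likely range from 4000 nM to 50000 nM.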

Compound 4, half-maximal inhibitory concentration: > 250000 nM
Compound 4: only a limit was reported; the forecaster's own chance of this, stated with the estimate: 10%; middle value at least 16-fold (1.22 log units) away from the limit.
By their numbers in this assay, from the lowest: compounds 3 and 1 (each within the scatter of the next); then compound 2. At a limit, above all of these: compound 4.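

In this assay, replacing the (1-bromoethenyl)carbonyl on the nitrogen with hydrogen, which leaves a plain amino group, is a very large change: an at least 430-fold higher number from compound 3 to compound 4 (2.63 log units; beyond the scatter). As far as these compounds go, compound 4 gives > 250000 nM, which is a limit of the assay and not a number, so the true size of this step stays unknown and it may be larger still. The result also shows that a methoxy on an aromatic carbon can count on the amino-bearing core, with an at least 15-fold higher number from compound 2 to compound 4 (1.19 log units; beyond the scatter), whereas the same change made no readable difference on the core carrying the (1-bromoethenyl)carbonyl: the same change on two cores in this assay, a 1.0-fold lower number (0.01 log units; within the scatter) from compound 1 to compound 3 and an at least 15-fold lower number (1.19 log units; beyond the scatter) from compound 4 to compound 2, at least 15-fold (1.17 log units) apart, beyond the scatter of two such steps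

The compounds shown leave open which part of the (1-bromoethenyl)carbonyl matters, as a simple acetyl group on the same nitrogen would keep the carbonyl without the bromine and the double bond. They also leave open whether the methoxy step on the amino-bearing core is specific to methoxy, or whether a hydroxyl or a fluorine on that aromatic carbon would give a similar step.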